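Replacing a cyclopropylmethyl with an aromatic five-membered ring

A few compounds are considered here, and "the series" means these few. Any claim that something is new, unique, unknown or untested is made for them only; others in the source may bear on it.

Measured so far:
compound 1 `C[C@@H](Oc1cc2oc(=O)n(CCC(=O)O)c2cc1Cl)c1ccc(Cl)cn1`, 2.65
compound 2 `O=C(O)CCn1c(=O)oc2cc(OCC3CC3)c(Cl)cc21`, 2.09
compound 3 `C[C@@H](Oc1cc2onc(CCC(=O)O)c2cc1Cl)c1ccccn1`, 1.99

In a physicochemical assay for lipophilicity, read by HPLC, at pH 7.4 (on this read-out lower numbers stand for lower lipophilicity and higher numbers for higher lipophilicity), compound 2 stands second highest of the three numbers. Its nearest neighbour is compound 3, lower by an amount within the scatter; the furthest is compound 1, higher by an amount beyond the scatter. Compound 4 `C[C@@H](Oc1cc2oc(=O)n(CCC(=O)O)c2cc1Cl)c1ncco1` differs from compound 2 in one place: a group of 7 heavy atoms (5 carbon, 1 nitrogen, 1 oxygen; one five-membered aromatic ring with 2 hetero atoms) in place of a group of 4 heavy atoms (4 carbon; one three-membered non-aromatic ring of carbon only), on an oxygen on an aromatic ring. For the measured compounds named here, no step between measured compounds isolates this change, so its size must be guessed. Compound 4 is expected to give a modest decrease in this assay, a number 0.39 log units lower from compound 2 to compound 4 (beyond the scatter), a step that may reach just beyond the scatter. The estimate for compound 4 is 1.7, with a range from 1.3 to 2.1.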

Compound 4, distribution coefficient: 1.11
Compound 4: middle estimate off by 0.59 log units, on the high side; measured number outside the range, below it.
By their numbers in this assay, from the lowest: compound 4; then compounds 3 and 2 (each within the scatter of the next); then compound 1.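

In this assay, the group on the oxygen on an aromatic ring can shift the number substantially: 1,3-oxazol-2-yl and its chain carbon in place of cyclopropylmethyl give a number 0.98 log units lower from compound 2 to compound 4 (beyond the scatter), while 1,3-oxazol-2-yl in place of 5-chloropyridin-2-yl gives a number 1.54 log units lower from compound 1 to compound 4 (beyond the scatter). The number for compound 4 therefore stays close to neither neighbour. Nothing available accounts for the size of these steps. Still open, on these data alone, is how much of the first step belongs to the ring and how much to the methyl branch that comes with the defined stereocentre. Also open, as far as these compounds go, is where a 1,3-thiazol-2-yl group, with sulfur in place of the ring oxygen, would fall.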